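A few compounds are considered here, and "the series" means these few. Any claim that something is new, unique, unknown or untested is made for them only; others in the source may bear on it.

Compound 2 `COc1ccc(-c2nn(-c3ccccc3)cc2C(=O)NOCc2ccccc2Cl)cc1` gives 3730 nM in a functional assay on MCF7 cells (Homo sapiens) for antiproliferative activity, read by MTT assay, with a stated time of 48 h, in the presence of a further agent that is not named here; a higher number here means a weaker inhibitor of growth, a lower number a stronger inhibitor of growth. Compound 1 `COc1ccc(-c2nn(-c3ccccc3)cc2C(=O)NOCc2ccccc2F)cc1` differs from it by fluoro in place of chloro on an aromatic carbon, a change that brought a 1.6-fold higher number from compound 2 to compound 1 (0.21 log units; within the scatter). In this assay compound 1 gives 6000 nM. Compound 3 `O=C(NOCc1ccccc1)c1cn(-c2ccccc2)nc1-c1ccc(Cl)cc1` carries a different core; the difference between the cores of compound 3 and compound 2 is not broken down here. In this assay compound 3 gives 10800 nM. Compound 4 `O=C(NOCc1ccccc1)c1cn(-c2ccccc2)nc1-c1ccc(F)cc1` differs from compound 3 by fluoro in place of chloro on an aromatic carbon; here the place is para to a large group, whereas in compound 1 it was ortho to a large group, so this is the same kind of change, not the same. Resting on the one earlier step of a 1.6-fold higher number from compound 2 to compound 1 (0.21 log units; within the scatter), compound 4 is expected to show a 1.5-fold higher number from compound 3 to compound 4 (0.17 log units; within the scatter) in this assay. The estimate for compound 4 is 16000 nM, expected to fall between 7500 nM and 35000 nM.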

Compound 4, concentration for 50% growth inhibition: 15300 nM
Estimate against measurement, compound 4: 1.0-fold (0.02 log units) above, and the stated range covers the measured number.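

In this assay, going by these compounds alone, the change from 4-chlorophenyl to 4-fluorophenyl brought a 1.4-fold higher number from compound 3 to compound 4 (0.15 log units; within the scatter) and so gives no step that stands clear of the scatter on this core. This does not show that the change has a real effect on growth inhibition on either core, and two cores, with the halogen at a different place on each, cannot establish a rule for the whole series. Still, nothing shown separates the two cores, as the two steps agree:
the same change on two cores in this assay, a 1.6-fold higher number (0.21 log units; within the scatter) from compound 2 to compound 1 and a 1.4-fold higher number (0.15 log units; within the scatter) from compound 3 to compound 4, 1.1-fold (0.06 log units) apart, within the scatter of two such steps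

The compounds shown leave open how an amine, a carboxylic acid or a nitrile would read in the place of the halogen. They also leave open whether a longer chain there would give a step beyond the scatter.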